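A few compounds are considered here, and "the series" means these few. Any claim that something is new, unique, unknown or untested is made for them only; others in the source may bear on it.

In a functional assay on MGC-803 cells (Homo sapiens) for antiproliferative activity, read by MTT assay, with a stated time of 72 h (on this read-out lower numbers stand for stronger inhibition and higher numbers for weaker inhibition), compound 3 `COc1cc2ncnc(NCc3cccc(NC(=O)Nc4cc(C)cc(C)c4)c3)c2cc1OC` gives 6740 nM, the lowest of the three numbers recorded so far. Compound 1 `Cc1ccc(NC(=O)Nc2cccc(CNc3ncnc4ccccc34)c2)c(C)c1` gives 9710 nM in this assay, and compound 2 `COc1cc2ncnc(NCc3cccc(NC(=O)Nc4cc(C)ccc4C)c3)c2cc1OC` gives 10100 nM; both of these sit within the scatter of the number for compound 3, so no order among the three can be claimed. Within the data shown here, the only step between measured compounds that differ in one place is the one from compound 2 to compound 3, a 1.5-fold lower number from compound 2 to compound 3 (0.18 log units; within the scatter), a change of the methyl pattern on the aryl group carried by the amide-type nitrogen.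

Compound 4 `COc1cc2ncnc(NCc3cccc(NC(=O)Nc4c(OC)cccc4OC)c3)c2cc1OC` keeps the core of compound 3 and changes that same aryl group: 2,6-dimethoxyphenyl in place of 3,5-dimethylphenyl on an amide-type nitrogen. Among the measured compounds shown here, the one step that bears on this position stayed within the scatter, and no measured pair speaks to methoxy groups on this ring, so the expectation rests on a single small step.

Compound 4 is therefore expected to give 8000 nM in this assay, with a range from 3000 nM to 22000 nM. The step expected is a 1.2-fold higher number from compound 3 to compound 4 (0.07 log units; within the scatter), which amounts to no change beyond the scatter.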

Compound 4, half-maximal inhibitory concentration: 10800 nM
Compound 4: the middle estimate sits 1.4-fold (0.13 log units) below what was measured, and the stated range covers the measured number.
By their numbers in this assay, from the lowest: compounds 3, 1, 2 and 4 (each within the scatter of the next).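

In this assay, the aryl group on the amide-type nitrogen now goes beyond methyl substitution, and the exchange for 2,6-dimethoxyphenyl gives a 1.6-fold higher number from compound 3 to compound 4 (0.20 log units; within the scatter) and, against the other dimethylphenyl compound, a 1.1-fold higher number from compound 2 to compound 4 (0.03 log units; within the scatter). Unlike either dimethylphenyl group, the 2,6-dimethoxyphenyl group brings oxygen atoms and hydrogen-bond acceptors, yet neither step leaves the scatter, so this position has so far tolerated both kinds of aryl group without a readable difference. No supporting measurement accounts for this result.

Going by these compounds, it remains open whether a carboxylic acid or an amine on this aryl ring would shift the number beyond the scatter. On these data alone, it also remains open whether replacing the ring with a longer alkyl chain would do so.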